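The source may hold more compounds than are shown below. What is called first, only, known or untested is meant among the compounds shown, and "the series" means these compounds.

In an ADME assay on L02 cells (Homo sapiens) for cytotoxicity, read by MTT assay (on this read-out lower numbers stand for stronger inhibition and higher numbers for weaker inhibition), compound 1 (`COc1ccc(/C=C/C(=O)c2ccc(OC)c3c2OC(C)(C)C=C3)cc1OC(=O)C(C)C`) gives > 10000 nM, which is a limit of the assay. Compound 2 (`COc1ccc(/C=C/C(=O)c2ccc(OC)c3c2OC(C)(C)C=C3)cc1OC(=O)C1CC1`) gives > 10000 nM, also a limit, and this is where it stands in this assay, with the limit of > 10000 nM in this assay, at which 2 of the 2 values shown sit. Compound 3 (`COc1ccc(/C=C/C(=O)c2ccc(OC)c3c2OC(C)(C)C=C3)cc1OC(=O)c1ccc(Br)cc1`) remains unmeasured and replaces the cyclopropyl of compound 2 with 4-bromophenyl on a carbonyl carbon: 4-bromophenyl in place of cyclopropyl on a carbonyl carbon. Going by the values given here, the sole measured step, a step that the two limits leave unreadable from compound 1 to compound 2, offers no readable size to carry over. No change beyond the scatter is therefore expected in this assay, and the expected step is a step that the limit leaves unreadable from compound 2 to compound 3. For compound 3, the estimated value is 15000 nM, with an expected range of 5000 nM to 50000 nM.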

Compound 3, half-maximal inhibitory concentration: 8400 nM
Compound 3: middle estimate off by 1.8-fold (0.25 log units), on the high side; the measured number falls inside the stated range.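

Going by these compounds alone, compound 3 gives the first number in this assay that is not a limit, so 4-bromophenyl on this carbonyl carbon can be placed on the scale, which isopropyl and cyclopropyl could not: the limit of > 10000 nM in this assay, at which 2 of the 3 values shown sit. Against those limits, the change reads as an at least 1.1-fold lower number from compound 2 to compound 3 (0.07 log units; that floor lies within the scatter), and as an at least 1.1-fold lower number from compound 1 to compound 3 (0.07 log units; that floor lies within the scatter). Going by these compounds, the true size of both steps remains unknown.

The compounds shown leave open whether the bromine or the aromatic ring carries this reading, and how a plain phenyl, a 4-chlorophenyl or an aminomethyl group would read on the same carbonyl carbon.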